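This account rests on a few compounds, and the source may have more. Where it says the series, first, only, none or still open, it means among the compounds named here.

Measured compounds:
compound 1, `CCC(=O)N[C@@H]1CCCc2c1cncc2N1Cc2cc(Cl)ccc2C1=O`
compound 2, `CCC(=O)N[C@@H]1CCCc2c1cncc2N1C(=O)c2ccc(Cl)cc2[C@@H]1C`
compound 3, `CCC(=O)N[C@@H]1CCCc2c1cncc2N1C(=O)c2ccc(Cl)cc2[C@H]1CC`

In an ADME assay on microsomes from liver (Mus musculus) for metabolic stability, read by LC-MS, using NADPH, with stated times of 10 min and 30 min (a higher number here means faster removal of the compound, a lower number slower removal), compound 1 gives < 20.2 mL/min/kg, which is a limit of the assay rather than a number. Compound 2 likewise sits at a limit, < 20.2 mL/min/kg. Compound 3 gives 44.9 mL/min/kg. The two steps read from these are a step that the two limits leave unreadable from compound 1 to compound 2 and an at least 2.2-fold higher number from compound 1 to compound 3 (0.34 log units; beyond the scatter); the first is obscured by the limit of < 20.2 mL/min/kg in this assay, at which 2 of the 3 values shown sit, the second is a readable rise. Both steps change a saturated ring carbon of the shared core.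

Compound 4, `CS(=O)(=O)N[C@@H]1CCCc2c1cncc2N1Cc2cc(Cl)ccc2C1=O`, differs from compound 1 at a different place: methylsulfonyl in place of propanoyl on an amine nitrogen. No measured step touches the amine nitrogen, so neither step bears on this change, and nothing among the shown compounds points to a direction. Compound 4 is therefore expected to stay close to compound 1 in this assay, a step that the limit leaves unreadable from compound 1 to compound 4, with the result most likely again at the limit. The estimate for compound 4 is 15 mL/min/kg, in the range 5 mL/min/kg to 40 mL/min/kg.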

Compound 4, clearance: < 20.2 mL/min/kg
Compound 4 was reported as a limit; the forecaster's own chance of this, stated with the estimate: 60%; the middle value lies beyond the limit too.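

No step can be read from compound 1 to compound 4 in this assay, with both compounds reported only as limits: the limit of < 20.2 mL/min/kg in this assay, at which 3 of the 4 values shown sit.

The compounds shown leave open whether methylsulfonyl in place of propanoyl on an amine nitrogen changes clearance at all.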